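Three Analogues at the Assay Ceiling and a Fourth

The source may hold more compounds than are shown below. What is called first, only, known or untested is meant among the compounds shown, and "the series" means these compounds.

Measured so far in an ADME assay on HUVEC cells (Homo sapiens) for antiproliferative activity, read by MTT assay, with a stated time of 48 h; a lower number here means a stronger inhibitor, a higher number a weaker inhibitor:
compound 1, `N#CC1=C(N)Oc2c(c3nc4ccccc4nc3c3ccccc23)C12C(=O)N(Cc1cnnn1-c1ccc(F)cc1)c1ccccc12` — compound 1 gives > 50000 nM
compound 2, `COc1ccc(-n2nncc2CN2C(=O)C3(C(C#N)=C(N)Oc4c3c3nc5ccccc5nc3c3ccccc43)c3ccccc32)cc1` — compound 2 gives > 50000 nM
compound 3, `Cc1ccc(C)c(-n2nncc2CN2C(=O)C3(C(C#N)=C(N)Oc4c(N)cc5nc6ccccc6nc5c43)c3ccccc32)c1` — compound 3 gives > 50000 nM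

Each of these values is a limit of the assay rather than a number. For compound 1 the result is such a limit. For compound 2 it is a limit as well. Compound 3 also stands at a limit, and this is the ceiling described by the limit of > 50000 nM in this assay, at which 3 of the 3 values shown sit. For the measured compounds named here, because of that ceiling, the only step between two measured compounds, a step that the two limits leave unreadable from compound 1 to compound 2, cannot be read in size or direction.

The new compound 4, `COc1cc(-n2nncc2CN2C(=O)C3(C(C#N)=C(N)Oc4c(N)cc5nc6ccccc6nc5c43)c3ccccc32)c(OC)cc1Cl`, differs from compound 3 in one place: 4-chloro-2,5-dimethoxyphenyl in place of 2,5-dimethylphenyl on an aromatic nitrogen. Going by the values given here, no measured step bears directly on this change; the step that the two limits leave unreadable from compound 1 to compound 2 alters a group on the same kind of aromatic carbon but tells nothing about size. With compound 3 at a limit, compound 4 is expected to remain near that ceiling, so the step that the limit leaves unreadable from compound 3 to compound 4 is estimated to be none beyond the scatter. For compound 4 the expected value is therefore 70000 nM, with a range from 20000 nM to 250000 nM.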

Compound 4, half-maximal inhibitory concentration: > 50000 nM
Compound 4 ended at the assay's limit; the forecaster's own chance of this, stated with the estimate: 85%; the middle value lies beyond the limit too.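

Compound 3 and compound 4 yield no readable step in this assay, because each result is a limit of the assay and not a number: the limit of > 50000 nM in this assay, at which 4 of the 4 values shown sit.

The compounds shown leave open how far past that limit each one truly lies, and whether swapping the group on the aromatic nitrogen changes activity at all.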